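From 4-methylpiperazin-1-yl to (diethylamino)methyl on a shared core

The source may report more compounds than this note shows. Statements on the series, on what has been measured and on what is new or still open speak of the compounds shown alone.

In an ADME assay on L6 cells (Rattus norvegicus) for cytotoxicity, read by resazurin assay, with a stated time of 72 h (on this read-out lower numbers stand for stronger inhibition and higher numbers for weaker inhibition), compound 1 `CN(C)C12CC(c3ccccc3)C(CN(CCN3CCCCC3)C1)C(c1ccccc1)C2` gives 2920 nM and compound 2 `CN1CCN(CCN2CC3C(c4ccccc4)CC(N(C)C)(CC3c3ccccc3)C2)CC1` gives 5260 nM. Going by the values given here, compound 2 therefore stands within the scatter of compound 1, the only other compound measured, and the two cannot be told apart on these numbers.

Compound 3 `CCN(CC)CCCN1CC2C(c3ccccc3)CC(N(C)C)(CC2c2ccccc2)C1` keeps the shared core and differs from compound 2 in one place: (diethylamino)methyl in place of 4-methylpiperazin-1-yl on a saturated chain carbon, two bonds along the chain from an amine nitrogen in a ring. In words, (diethylamino)methyl stands in place of 4-methylpiperazin-1-yl on a saturated chain carbon, two bonds along the chain from an amine nitrogen in a ring.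

Among the compounds with values here, one measured step bears on this change, as it swaps the group at the same place: a 1.8-fold higher number from compound 1 to compound 2 (0.26 log units; within the scatter). Neither measured compound carries a group without a ring there, so this guide is thin. On that single step, no change beyond the scatter is expected in this assay. The estimated change is a 1.3-fold lower number from compound 2 to compound 3 (0.12 log units; within the scatter). Compound 3 is expected at 4000 nM, with an estimated range of 1700 nM to 9000 nM.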

Compound 3, half-maximal inhibitory concentration: 3270 nM
The estimate for compound 3 lay 1.2-fold (0.09 log units) above the measured number, within the range that was stated.
By their numbers in this assay, from the lowest: compounds 1, 3 and 2 (each within the scatter of the next).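

Going by these compounds alone, the first group without a ring at this place, (diethylamino)methyl, gives in this assay a 1.6-fold lower number from compound 2 to compound 3 (0.21 log units; within the scatter) and, set against the piperidin-1-yl group, a 1.1-fold higher number from compound 1 to compound 3 (0.05 log units; within the scatter). Within the data shown here, the earlier pair compared only two ring-bearing groups, whereas these steps show that, on a saturated chain carbon, two bonds along the chain from an amine nitrogen in a ring, the loss of that ring leaves the number within the scatter of both ring-bearing compounds. All three groups therefore cannot be told apart in this assay, and no measurement shown offers an explanation for this result.

All three groups carry an amine nitrogen, so the compounds leave open whether a carboxylic acid, a hydroxyl or a phenyl group at this place would shift the number in this assay beyond the scatter. They also leave open whether a longer chain carrying the diethylamino group would stay within the scatter of these three compounds.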